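A Halogen Shift on the Aniline Ring of Compound 3

This account rests on a few compounds, and the source may have more. Where it says the series, first, only, none or still open, it means among the compounds named here.

For the measured compounds named here, compound 3 `C=CC(=O)Nc1cccc(NC(=O)CSc2nc(Nc3ccccc3Cl)c3ccccc3n2)c1` carries the largest number among the three compounds measured so far: in a functional assay on MGC-803 cells (Homo sapiens) for inhibition, read by MTT assay, with a stated time of 72 h (on this read-out lower numbers stand for stronger inhibition and higher numbers for weaker inhibition), compound 3 gives 20700 nM. Its gap to compound 1 `O=C(CSc1nc(Nc2ccccc2)c2ccccc2n1)Nc1cccc(Cl)c1`, which in this assay gives 14300 nM, lies within the scatter, while its gap to compound 2 `O=C(CSc1nc(Nc2ccccc2)c2ccccc2n1)Nc1ccc(C(F)(F)F)cc1`, which gives 8670 nM, lies beyond it.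

Compound 4 `C=CC(=O)Nc1cccc(NC(=O)CSc2nc(Nc3cccc(Br)c3)c3ccccc3n2)c1` is the next compound, differing from compound 3 by 3-bromophenyl in place of 2-chlorophenyl on a nitrogen on an aromatic ring. Going by the values given here, the single measured step, a 1.6-fold lower number from compound 1 to compound 2 (0.22 log units; within the scatter), concerns the aryl group on the amide-type nitrogen and not the nitrogen on the aromatic ring that is changed here, so no measured pair speaks directly to this change. That one step, exchanging one halogenated aryl for another at a different position, stayed within the scatter. In the absence of a closer precedent, a change of this kind is therefore expected to move the number little, with no step beyond the scatter and a slight lean toward a lower number at most.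

The estimated step from compound 3 to compound 4 is a 1.4-fold lower number from compound 3 to compound 4 (0.14 log units; within the scatter). Compound 4 is thus expected to give about 15000 nM in this assay, within a range from 6000 nM to 40000 nM.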

Compound 4, half-maximal inhibitory concentration: 11900 nM
For compound 4 the middle estimate is 1.3-fold (0.10 log units) above the measured one; the measured number falls inside the stated range.
By their numbers in this assay, from the lowest: compounds 2, 4, 1 and 3 (each within the scatter of the next, the first and the last beyond it).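

The step on the nitrogen on an aromatic ring, the first measured at this position, comes to a 1.7-fold lower number from compound 3 to compound 4 (0.24 log units; within the scatter) in this assay, so compound 4 and compound 3 cannot be told apart on this read-out. It shows that this position tolerates the exchange of 2-chlorophenyl for 3-bromophenyl, in which both the halogen and its place on the ring differ, without a change beyond the scatter, which the earlier step on the amide-type nitrogen could not show for this site. Nothing at hand bears on what lies behind this result.

The compounds shown leave open whether the halogen or its place on the ring matters more, as the two differ together in this one step and no compound shown separates them. They also leave open how the number would respond if the halogen on this phenyl ring gave way to a group of another kind, such as an amine, a methoxy group or a carboxylic acid.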